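This account rests on a few compounds, and the source may have more. Where it says the series, first, only, none or still open, it means among the compounds named here.

The measured compounds:

Compound 1, `O=C1NC(=O)/C(=C/C2=Cc3ccccc3OC2)S1`, gives 99400 nM in a functional assay on MCF7 cells (Homo sapiens) for antiproliferative activity, read by MTT assay, with a stated time of 72 h; a higher number here means a weaker inhibitor, a lower number a stronger inhibitor.
Compound 2, `O=C1NC(=O)/C(=C/C2=Cc3ccccc3OC2)N1`, gives 8100 nM in this assay.
Compound 3, `O=C1NC(=O)/C(=C/C2=Cc3cc(Br)ccc3OC2)S1`, gives 57900 nM in this assay.

Compounds 1 and 3 share one core, compound 2 carries another; the difference between the two cores is not broken down here. Compound 2 stands apart from both others: its number in this assay is lower than that of compound 3 and that of compound 1 by amounts beyond the usual scatter, so compound 2 is the strongest inhibitor of the three.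

Within the first core, the change from compound 1 to compound 3 is bromo in place of hydrogen on an aromatic carbon. It made a 1.7-fold lower number from compound 1 to compound 3 (0.23 log units; within the scatter), a step that is not distinguishable from repeat measurement noise.

Compound 4, `O=C1NC(=O)/C(=C/C2=Cc3cc(Br)ccc3OC2)N1`, has not yet been measured in this assay. It arises from compound 2 by bromo in place of hydrogen on an aromatic carbon, the same change, at the same place, that turns compound 1 into compound 3. Going by the values given here, since the only example of this change moved the number by a 1.7-fold lower number from compound 1 to compound 3 (0.23 log units; within the scatter), a step of about the same size is expected here, so the estimated change is a 1.5-fold lower number from compound 2 to compound 4 (0.17 log units; within the scatter). Compound 4 is therefore estimated to give about 5500 nM in this assay, most likely between 2000 nM and 15000 nM.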

Compound 4, half-maximal inhibitory concentration: 51000 nM
Beside the measured number, compound 4's estimate is 9.3-fold (0.97 log units) below it; measured number outside the range, above it.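

In this assay, going by these compounds alone, bromo in place of hydrogen on an aromatic carbon made a 6.3-fold higher number from compound 2 to compound 4 (0.80 log units; beyond the scatter), so adding the bromo weakened the inhibitor on this core, whereas the same change on the core of compound 1 gave no step that stands out from repeat measurements. Set side by side, the two steps are clearly different, by more than the scatter of two such steps allows: the same change on two cores in this assay, a 1.7-fold lower number (0.23 log units; within the scatter) from compound 1 to compound 3 and a 6.3-fold higher number (0.80 log units; beyond the scatter) from compound 2 to compound 4, 11-fold (1.03 log units) apart, beyond the scatter of two such steps. Within the data shown here, this shows that, in this series, a step read on one core cannot simply be carried over to the other, but it does not show why the two cores respond differently, and with only one pair of compounds on each core it offers no general rule for either.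

The compounds shown leave open whether other groups on the same aromatic carbon, such as chloro, methoxy or an amine, would also part the two cores or would behave alike on both. They also leave open whether bromo placed on a different carbon of that six-membered aromatic ring would repeat this split between the cores.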